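The source may hold more compounds than are shown below. What is called first, only, known or untested is meant among the compounds shown, and "the series" means these compounds.

Series notes, compound 2 to compound 3.

Compound 1 `Fc1ccccc1Cn1nc(-c2ncc(F)c(N3CCCCC3)n2)cc1-c1ccon1` carries a piperidin-1-yl group on the shared core; in an assay on a protein complex for activation of soluble guanylate cyclase (Homo sapiens), read by cGMP accumulation, in the presence of a further agent that is not named here (on this read-out higher numbers stand for an effect only at larger amounts of compound and lower numbers for an effect already at smaller amounts), compound 1 gives 27 nM. Compound 2 `OC1CCCN(c2nc(-c3cc(-c4ccon4)n(Cc4ccccc4F)n3)ncc2F)C1` adds a hydroxy group on that saturated ring; in this assay compound 2 gives 33 nM. Among the compounds with values here, on the two numbers so far, compound 2 sits alongside compound 1, the pair lying within the scatter of one another, since a 1.2-fold higher number from compound 1 to compound 2 (0.09 log units; within the scatter).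

Compound 3 `OC1CCN(c2nc(-c3cc(-c4ccon4)n(Cc4ccccc4F)n3)ncc2F)CC1` is the next member. It differs from compound 2 as 4-hydroxypiperidin-1-yl in place of 3-hydroxypiperidin-1-yl on an aromatic carbon, the two having the same atoms joined differently.

Within the data shown here, only one measured step bears on this change: the introduction of the hydroxy group itself, a 1.2-fold higher number from compound 1 to compound 2 (0.09 log units; within the scatter), which did not move the number beyond the scatter. Among the measured compounds shown here, no measured pair yet shows what shifting the hydroxy group around the saturated ring does, so the expectation rests on that single step alone. The working expectation is a step of a 1.1-fold higher number from compound 2 to compound 3 (0.03 log units; within the scatter), that is, none beyond the scatter.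

Compound 3 is therefore estimated at 35 nM, with a range of 15 nM to 85 nM.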

Compound 3, half-maximal effective concentration: 10 nM
Compound 3: the middle estimate sits 3.5-fold (0.54 log units) above what was measured; measured number outside the range, below it.
By their numbers in this assay, from the lowest: compound 3; then compounds 1 and 2 (each within the scatter of the next).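

Where the hydroxy sits on the saturated ring matters in this assay, which the earlier pair could not show: a 3.3-fold lower number from compound 2 to compound 3 (0.52 log units; beyond the scatter), although the group leaving and the group entering have the same atoms and stand on the same aromatic carbon, ortho to a fluoro group. The effect of adding a hydroxy to the piperidin-1-yl group of compound 1 also turns out to depend on its ring position in these three compounds, since a 1.2-fold higher number from compound 1 to compound 2 (0.09 log units; within the scatter), whereas a 2.7-fold lower number from compound 1 to compound 3 (0.43 log units; beyond the scatter). No measurement at hand explains why 4-hydroxypiperidin-1-yl and 3-hydroxypiperidin-1-yl part in this way.

The compounds shown leave open whether the hydroxy itself is needed at the place it holds in 4-hydroxypiperidin-1-yl, or whether a methoxy, an amine or a carboxylic acid there would serve equally. They also leave open whether a longer chain such as hydroxymethyl on the same ring carbon would keep the lower number seen with compound 3, and whether a smaller saturated ring such as a hydroxypyrrolidine would do the same.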